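The source may hold more compounds than are shown below. What is called first, only, known or untested is meant among the compounds shown, and "the series" means these compounds.

Measured so far:
compound 1 `Cn1ncc2c(NC(=O)NCc3cc(C(F)(F)F)nn3-c3ccc(Cl)cc3)cccc21`, 2.7 nM
compound 2 `Cn1ncc2c(NC(=O)NCc3cc(C(F)(F)F)nn3-c3ccc(F)cc3)cccc21`, 8.4 nM
compound 3 `Cn1ncc2c(NC(=O)NCc3cc(C(F)(F)F)nn3-c3ccc(F)c(F)c3)cccc21`, 4.9 nM

All three share one core and differ only in the groups on the phenyl ring attached to the aromatic nitrogen. In an assay on CHO-K1 cells for antagonist activity at transient receptor potential cation channel subfamily V member 1 (Homo sapiens), read by FLIPR and calcium flux, with a stated time of 6 min (a higher number here means a weaker inhibitor, a lower number a stronger inhibitor), compound 1 gives 2.7 nM. The change from compound 2 to compound 1 is chloro in place of fluoro on an aromatic carbon, and it produced a 3.1-fold lower number from compound 2 to compound 1 (0.49 log units; beyond the scatter). Compound 3 differs from compound 2 by fluoro in place of hydrogen on an aromatic carbon, which gave a 1.7-fold lower number from compound 2 to compound 3 (0.23 log units; within the scatter).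

Compound 4 `Cn1ncc2c(NC(=O)NCc3cc(C(F)(F)F)nn3-c3ccc(F)c(Cl)c3)cccc21` is not yet measured. It differs from compound 3 by chloro in place of fluoro on an aromatic carbon. This is the same kind of change as that from compound 2 to compound 1, but not the same: there the chloro sits para to a large group, here it sits ortho to a fluoro group and meta to a large group. Resting on compound 1 and its step of a 3.1-fold lower number from compound 2 to compound 1 (0.49 log units; beyond the scatter), the expected step is a 2.0-fold lower number from compound 3 to compound 4 (0.29 log units; within the scatter), somewhat smaller to allow for the different surroundings. Compound 4 is thus estimated at 2.5 nM, expected to fall between 1 nM and 6 nM.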

Compound 4, inhibition constant: 1.9 nM
For compound 4 the middle estimate is 1.3-fold (0.12 log units) above the measured one; measured number inside the range.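

Chloro in place of fluoro gave a 2.6-fold lower number from compound 3 to compound 4 (0.41 log units; beyond the scatter) in this assay and this agrees with the earlier step on the other core: the same change on two cores in this assay, a 3.1-fold lower number (0.49 log units; beyond the scatter) from compound 2 to compound 1 and a 2.6-fold lower number (0.41 log units; beyond the scatter) from compound 3 to compound 4, 1.2-fold (0.08 log units) apart, within the scatter of two such steps.

So the change carried over in these two cases, even though the chloro in compound 4 sits ortho to a fluoro group, but two pairs set no rule for other cores and do not explain why the number drops. Chloro in place of hydrogen gave a 4.4-fold lower number from compound 2 to compound 4 (0.65 log units; beyond the scatter) while 3-chloro-4-fluorophenyl in place of 4-chlorophenyl gave a 1.4-fold lower number from compound 1 to compound 4 (0.15 log units; within the scatter) so compound 1 and compound 4 cannot be told apart here.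

The compounds shown leave open how a methyl, methoxy or nitrile group would read in place of the chloro. They also leave open whether the same step would hold with a group such as tert-butyl in place of the trifluoromethyl on the shared core.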